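A few compounds are considered here, and "the series" means these few. Any claim that something is new, unique, unknown or untested is made for them only; others in the source may bear on it.

Measured compounds:
compound 1 `O=[N+]([O-])c1cccc(COc2ccc(OCCOCCNC3CCCC3)cc2)c1` gives 15400 nM in a functional assay on SK-OV-3 cells (Homo sapiens) for inhibition, read by CCK-8 assay, with a stated time of 70 h; a lower number here means a stronger inhibitor, a higher number a weaker inhibitor
compound 2 `Clc1ccc(COc2ccc(OCCOCCNC3CCCCC3)cc2)cc1` gives 2650 nM in this assay
compound 3 `c1ccc(COc2ccc(OCCOCCNC3CC3)cc2)cc1` gives 47200 nM in this assay

Among these three numbers, compound 1 stands second highest. Its nearest neighbour is compound 3, whose number is higher, and the gap between the two is beyond the usual scatter. Compound 2 lies furthest away, with a lower number, again beyond the scatter. No two of these compounds differ in only one place, so none of these gaps can be tied to a single structural change.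

Compound 4 `O=C(O)c1cccc(COc2ccc(OCCOCCNC3CCCC3)cc2)c1` has not yet been measured in this assay. It differs from compound 1 in one spot: carboxy in place of nitro on an aromatic carbon. The two groups are of the same size, yet they swap a hydrogen-bond acceptor for a donor.

Within the data shown here, with no directly comparable pair available, the expectation rests on the change alone. A modest weakening is expected, so the step of a 1.9-fold higher number from compound 1 to compound 4 (0.29 log units; within the scatter) is estimated to run toward a higher number, close to the edge of the scatter. Compound 4 is therefore expected to give about 30000 nM, most likely between 10000 nM and 90000 nM.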

Compound 4, half-maximal inhibitory concentration: > 100000 nM
Compound 4: a limit, no number (the forecaster's own chance of this, stated with the estimate: 15%); middle value at least 3.3-fold (0.52 log units) away from the limit.
By their numbers in this assay, from the lowest: compound 2; then compound 1; then compound 3. At a limit, above all of these: compound 4.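

Among these compounds, this is the first change in the set that can be tied to one place: carboxy in place of nitro on the aromatic carbon gives an at least 6.4-fold higher number from compound 1 to compound 4 (0.81 log units; beyond the scatter) in this assay. The two groups have the same count of heavy atoms, so this aromatic carbon does not accept every group of that size equally, although carboxy carries a hydrogen-bond donor where nitro has none. Compound 4 sits at a limit of the assay, not at a true number: the limit of > 100000 nM in this assay, at which 1 of the 4 values shown sits.

Going by these compounds, how much weaker compound 4 really is stays unknown. One pair cannot separate the donor from any other difference between the groups. A methyl ester, a primary amide or an amine at the same aromatic carbon could help show which feature of carboxy matters.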